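Replacing a methyl with a fluoro on compound 3

A few compounds are considered here, and "the series" means these few. Any claim that something is new, unique, unknown or untested is made for them only; others in the source may bear on it.

Compound 1 `CSc1ccc(C2=C(c3ccc(C)c(C)c3)C(=O)N3CCCC3C2)cc1` gives 700 nM in growth inhibition
Compound 2 `CSc1ccc(C2=C(c3ccc(O)c(O)c3)C(=O)N3CCCC3C2)cc1` gives 50000 nM in growth inhibition
Compound 3 `CSc1ccc(C2=C(c3ccc(C)cc3)C(=O)N3CCCC3C2)cc1` gives 3000 nM in growth inhibition

In a functional assay on SW-620 cells (Homo sapiens) for cytotoxicity (a lower number here means a stronger inhibitor of growth, a higher number a weaker inhibitor of growth), compound 3 stands in the middle of the three, with a higher number than compound 1 and a lower number than compound 2. Compound 4 `CSc1ccc(C2=C(c3ccc(F)cc3)C(=O)N3CCCC3C2)cc1` carries fluoro in place of methyl on an aromatic carbon. Among the compounds with values here, no measured step makes this swap. The closest is the modest step on losing a methyl (a 4.3-fold higher number from compound 1 to compound 3 (0.63 log units; beyond the scatter)). The large steps (a 71-fold higher number from compound 1 to compound 2 (1.85 log units; beyond the scatter)) and (a 17-fold lower number from compound 2 to compound 3 (1.22 log units; beyond the scatter)) involve the 3,4-dihydroxyphenyl group of compound 2, so they say little here. The expected step is small and no larger than the scatter (a 1.3-fold higher number from compound 3 to compound 4 (0.12 log units; within the scatter)), leaning slightly towards a higher number. The estimate for compound 4 is 4000 nM (expected range 1500 nM to 11000 nM).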

Compound 4, concentration for 50% growth inhibition: 500 nM
Beside the measured number, compound 4's estimate is 8.0-fold (0.90 log units) above it, outside the stated range (below it).
By their numbers in this assay, from the lowest: compounds 4 and 1 (each within the scatter of the next); then compound 3; then compound 2.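

Fluoro in place of methyl, para to a large group, is a real gain in this assay (a 6.0-fold lower number from compound 3 to compound 4 (0.78 log units; beyond the scatter)), which shows that this single atom matters more than the earlier steps suggested. The 4-fluorophenyl and 3,4-dimethylphenyl groups cannot be told apart here (a 1.4-fold lower number from compound 1 to compound 4 (0.15 log units; within the scatter)), while the 3,4-dihydroxyphenyl group stays far behind (a 100-fold lower number from compound 2 to compound 4 (2.00 log units; beyond the scatter)). Nothing available explains why fluoro outperforms methyl here. Whether the gain is particular to fluoro stays open, since chloro, methoxy, nitrile or an amine at this place are not among the compounds shown.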